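The compounds below may be only part of what the source reports. "The series", "measured", "known", "first", "only" and "open" are said of these compounds alone.

Compound 3 `C[S+]([O-])CCn1c(=N)sc2cc(OC(F)(F)F)ccc21` is one of three compounds sharing a core. In a functional assay on the whole organism with Rattus norvegicus as the target (a higher number here means that more compound is needed for the effect, a lower number that less compound is needed), compound 3 gives 1.1 mg/kg, which is the second highest number of the three; compound 2 `CSCCn1c(=N)sc2cc(OC(F)(F)F)ccc21` gives 1 mg/kg, and compound 1 `C#CCn1c(=N)sc2cc(OC(F)(F)F)ccc21` gives 4 mg/kg. The step from compound 2 to compound 3 was a 1.1-fold higher number from compound 2 to compound 3 (0.04 log units; within the scatter), while a 3.6-fold lower number from compound 1 to compound 3 (0.56 log units; beyond the scatter) and a 4.0-fold lower number from compound 1 to compound 2 (0.60 log units; beyond the scatter) came from replacing the whole side chain.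

Compound 4 `N=c1sc2cc(OC(F)(F)F)ccc2n1CCN1CCCCC1` differs from compound 3 at the same place as compound 2 did: a group of 6 heavy atoms (5 carbon, 1 nitrogen; one six-membered non-aromatic ring with 1 hetero atom) in place of a group of 3 heavy atoms (1 carbon, 1 oxygen, 1 sulfur; no ring), on a saturated chain carbon, two bonds along the chain from an aromatic nitrogen. Going by the values given here, the only step at that place, a 1.1-fold higher number from compound 2 to compound 3 (0.04 log units; within the scatter), was small, and no measured step tests a ring group there. Compound 4 is therefore expected to show a 1.1-fold higher number from compound 3 to compound 4 (0.04 log units; within the scatter), roughly no change beyond the scatter. Compound 4 is estimated at 1.2 mg/kg, with a range from 0.4 mg/kg to 4 mg/kg.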

Compound 4, dose for half-maximal effect: 2 mg/kg
Beside the measured number, compound 4's estimate is 1.7-fold (0.22 log units) below it; the measured number falls inside the stated range.
By their numbers in this assay, from the lowest: compounds 2, 3, 4 and 1 (each within the scatter of the next, the first and the last beyond it).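

In this assay the piperidin-1-yl ring, the first ring group seen on this chain, gives a 1.8-fold higher number from compound 3 to compound 4 (0.26 log units; within the scatter) and a 2.0-fold higher number from compound 2 to compound 4 (0.30 log units; within the scatter) so the ring cannot be told apart from either open-chain group. Compound 4 also shows a 2.0-fold lower number from compound 1 to compound 4 (0.30 log units; within the scatter) whereas compound 2 and compound 3 each stood clear of compound 1, so the ring does not clearly keep that separation. Nothing available here explains this result. From the compounds shown here alone, whether a morpholin-4-yl ring, an open-chain amine such as dimethylamino, or a longer chain before the piperidin-1-yl ring would fall in the same range stays open.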